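The source may report more compounds than this note shows. Statements on the series, on what has been measured and on what is new or still open speak of the compounds shown alone.

In a functional assay for inhibition, with Homo sapiens as the target (a higher number here means a weaker inhibitor, a lower number a stronger inhibitor), the read-out is a half-maximal inhibitory concentration. Compound 1 `O=C(/C=C/c1ccccc1)c1ccccc1OCc1ccccc1` gives 2230 nM, and compound 2 `O=C(/C=C/c1ccccc1)c1ccccc1C(F)(F)F` gives 748 nM, the lower of the two numbers and so the stronger inhibitor of this pair. The next compound is compound 3 `O=C(/C=C/c1ccccc1)c1ccccc1Br`, which carries bromo in place of trifluoromethyl on an aromatic carbon. Among the measured compounds shown here, only one measured step bears on this change: a 3.0-fold lower number from compound 1 to compound 2 (0.47 log units; beyond the scatter), a modest move beyond the scatter, with trifluoromethyl in place of benzyloxy on an aromatic carbon. For the measured compounds named here, that step shows that the number can respond to a change of group at this carbon, but it involves no bromo, and no measurement yet shows what bromo does here. The data therefore give no direction for the new change, and the expectation is for no step beyond the scatter in this assay, with wide uncertainty. The estimated move is a 1.2-fold higher number from compound 2 to compound 3 (0.08 log units; within the scatter). Compound 3 is expected at about 900 nM, with an estimated range from 300 nM to 2700 nM.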

Compound 3, half-maximal inhibitory concentration: 1660 nM
Estimate against measurement, compound 3: 1.8-fold (0.27 log units) below; low and high end bracket the measured number.
By their numbers in this assay, from the lowest: compound 2; then compounds 3 and 1 (each within the scatter of the next).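

In this assay the swap of trifluoromethyl for bromo on this aromatic carbon is not neutral: it gives a 2.2-fold higher number from compound 2 to compound 3 (0.35 log units; beyond the scatter) and leaves compound 2 as the strongest inhibitor of the three. Bromo and benzyloxy, however, cannot be told apart in this series, since the measured step is a 1.3-fold lower number from compound 1 to compound 3 (0.13 log units; within the scatter) and the number does not clearly respond to that exchange. Of the three groups tried at this carbon, only trifluoromethyl stands apart, so the earlier improvement over compound 1 does not come with just any replacement of benzyloxy. No available measurement explains why trifluoromethyl differs from the other two groups.

The compounds shown leave open how other groups at this carbon would compare, such as methoxy, an amine or a carboxylic acid, and whether trifluoromethyl would still stand apart among them. They also leave open whether exchanging trifluoromethyl for bromo would produce a step of similar size on a different core.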